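Carbamoyl for Amine on the Chain of Compound 3

The compounds below may be only part of what the source reports. "The series", "measured", "known", "first", "only" and "open" are said of these compounds alone.

Among the compounds with values here, compound 2 `CCCCCCCCCCCC[C@@H](O)[C@H]1CC[C@H]([C@H](O)CCCCCCCCCCNCc2ccnn2C)O1` holds the lower of the two numbers measured so far in a functional assay on OVCAR-3 cells (Homo sapiens) for inhibition, read by sulforhodamine B assay, with a stated time of 48 h; on this read-out lower numbers stand for stronger inhibition of growth and higher numbers for weaker inhibition of growth. In this assay compound 2 gives 1510 nM, while compound 1 `CCCCCCCCCCCC[C@@H](O)[C@H]1CC[C@H]([C@H](O)CCCCCCCCCCN(C)C(=O)c2ccnn2C)O1` gives 10000 nM.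

Compound 3 `CCCCCCCCCCCC[C@@H](O)[C@H]1CC[C@H]([C@H](O)CCCCCCCCCCC(=O)Nc2ccnn2C)O1` has not yet been measured. It keeps the shared core of compound 2 and differs only at the end of the chain: (1-methyl-1H-pyrazol-5-yl)carbamoyl in place of ((1-methyl-1H-pyrazol-5-yl)methyl)amino on a saturated chain carbon, ten or more bonds along the chain from an oxygen on a saturated carbon and a saturated ring carbon. The change sits on a saturated chain carbon.

Within the data shown here, only one measured step bears on this change: a 6.6-fold lower number from compound 1 to compound 2 (0.82 log units; beyond the scatter). In that modest step, ((1-methyl-1H-pyrazol-5-yl)methyl)amino took the place of a group carrying a carbonyl. Compound 3 brings a carbonyl back, though within a different group, so this single step is only a loose guide. A similar move towards weaker inhibition of growth is therefore expected, and the expected step is a 3.0-fold higher number from compound 2 to compound 3 (0.47 log units; beyond the scatter). For compound 3 the estimate is 4500 nM, with an expected range from 1400 nM to 14000 nM.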

Compound 3, concentration for 50% growth inhibition: 100000 nM
Compound 3: middle estimate off by 22-fold (1.35 log units), on the low side; the whole stated range lies below it.
By their numbers in this assay, from the lowest: compound 2; then compound 1; then compound 3.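

In this assay, within the data shown here, the move from the ((1-methyl-1H-pyrazol-5-yl)methyl)amino group to the (1-methyl-1H-pyrazol-5-yl)carbamoyl group gives a 66-fold higher number from compound 2 to compound 3 (1.82 log units; beyond the scatter), which shows that this chain end tolerates this change far less well than the single earlier step could suggest. The two carbonyl-bearing groups also differ clearly, with the (1-methyl-1H-pyrazol-5-yl)carbamoyl group giving a 10-fold higher number from compound 1 to compound 3 (1.00 log units; beyond the scatter), so the presence of a carbonyl alone does not fix the number at this position, and among these three compounds the lowest number stays with the amine of compound 2. No measurement is available that accounts for the size of these steps.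

The compounds shown leave open whether the lower number of compound 2 depends on the 1-methylpyrazole ring or would persist with a plain primary amine or a dimethylamino group at the same place. They also leave open whether a methyl group on the amide nitrogen of compound 3, or a longer chain before the amide, would change its number.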